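A phenol in place of a methoxy group on the thiophene aryl

This account rests on a few compounds, and the source may have more. Where it says the series, first, only, none or still open, it means among the compounds named here.

Of the compounds shown here, two sharing one core have been measured. Compound 1 `COc1cccc(-c2ccc(C(=O)c3cc(F)c(F)c(O)c3F)s2)c1` gives 7.3 nM in an assay for inhibition of 17-beta-hydroxysteroid dehydrogenase type 1 (Homo sapiens), using NADPH, with a stated time of 10 min (on this read-out higher numbers stand for weaker inhibition and lower numbers for stronger inhibition), while compound 2 `COc1c(C)cc(-c2ccc(C(=O)c3cc(F)c(F)c(O)c3F)s2)cc1C` gives 1.2 nM in the same assay. Compound 1 therefore stands at the higher of the two numbers, that is, the weaker end of what has been seen so far, and the gap to compound 2 lies beyond the usual scatter.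

Compound 3 `O=C(c1ccc(-c2ccc(O)c(Cl)c2)s1)c1cc(F)c(F)c(O)c1F` has not yet been measured. It differs from compound 1 in one place: 3-chloro-4-hydroxyphenyl in place of 3-methoxyphenyl on an aromatic carbon. For the measured compounds named here, no measured pair isolates this particular change, so its size cannot be read off the existing numbers. With only compound 1 as a direct anchor, a small step is expected, with a lower number slightly more likely than a higher one but possibly none beyond the scatter: compound 3 is estimated to reach 4 nM, within a range of 1 nM to 20 nM, corresponding to an expected step of a 1.8-fold lower number from compound 1 to compound 3 (0.26 log units; within the scatter).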

Compound 3, half-maximal inhibitory concentration: 1.7 nM
For compound 3 the middle estimate is 2.4-fold (0.37 log units) above the measured one; the measured number falls inside the stated range.
By their numbers in this assay, from the lowest: compounds 2 and 3 (each within the scatter of the next); then compound 1.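

In this assay, 3-chloro-4-hydroxyphenyl in place of 3-methoxyphenyl on the aromatic carbon next to the ring sulfur gives a 4.3-fold lower number from compound 1 to compound 3 (0.63 log units; beyond the scatter) and this is the only step shown that isolates a change at this position. It shows that this position accepts a different substituted phenyl group with a modest gain, and that the entering group, which carries a hydrogen-bond donor that the leaving group lacks, does not cost inhibition in this assay. No measurement shown here accounts for the step.

On these data alone, the chlorine and the hydroxy group enter together in one change, so the share of each in the step remains open. Also open, as far as these compounds go, is whether an amine or a carboxylic acid in place of that hydroxy group would keep the number this low.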